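Replacing One Phenyl Group With a Smaller One

The source may report more compounds than this note shows. Statements on the series, on what has been measured and on what is new or still open speak of the compounds shown alone.

In a functional assay on A549 cells (Homo sapiens) for cytotoxicity, read by MTT assay, with a stated time of 72 h (on this read-out lower numbers stand for stronger inhibition and higher numbers for weaker inhibition), compound 1 (`COc1cc2ncnc(Nc3ccc(F)c(Cl)c3)c2cc1NC(=O)N/N=C/c1cc(OC)c(OC)c(OC)c1`) gives 32100 nM, and compound 2 (`CCN(CC)c1ccc(/C=N/NC(=O)Nc2cc3c(Nc4ccc(F)c(Cl)c4)ncnc3cc2OC)c(O)c1`) gives 27300 nM. Going by the values given here, these are the only two numbers so far, and they lie within the usual scatter of each other, so compound 2 stands level with compound 1.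

Compound 3 (`COc1cc2ncnc(Nc3ccc(F)c(Cl)c3)c2cc1NC(=O)N/N=C/c1ccc(O)cc1`) has not yet been measured. It keeps the rest of compound 2 but carries 4-hydroxyphenyl in place of 4-(diethylamino)-2-hydroxyphenyl on a carbon with a double bond to nitrogen.

Among the compounds with values here, only one measured step bears on this change. That step, a 1.2-fold lower number from compound 1 to compound 2 (0.07 log units; within the scatter), also exchanged the group at this same place. Within the data shown here, it is thin evidence, since no measured compound carries 4-hydroxyphenyl. Even so, no step beyond the scatter is expected in this assay, and neither direction is favoured. The estimate amounts to an expected 1.0-fold higher number from compound 2 to compound 3 (0.01 log units; within the scatter). Compound 3 is expected to give about 28000 nM, with an estimated range from 11000 nM to 70000 nM.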

Compound 3, half-maximal inhibitory concentration: 7610 nM
The estimate for compound 3 lay 3.7-fold (0.57 log units) above the measured number; the measured number lies below the stated range.
By their numbers in this assay, from the lowest: compound 3; then compounds 2 and 1 (each within the scatter of the next).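

In this assay, the group on the carbon with a double bond to nitrogen proves able to shift the number: 4-hydroxyphenyl gives a 3.6-fold lower number from compound 2 to compound 3 (0.55 log units; beyond the scatter) and also a 4.2-fold lower number from compound 1 to compound 3 (0.63 log units; beyond the scatter) when it takes the place of 3,4,5-trimethoxyphenyl. The two earlier compounds stood level, so they gave no sign that this place responds to any change, whereas the smaller 4-hydroxyphenyl group now separates itself from both larger groups. Nothing measured here gives a reason for this stronger inhibition.

The step from compound 2 to compound 3 removes the diethylamino group and also changes the hydroxyl from the 2-hydroxy to the 4-hydroxy arrangement, so the compounds shown leave open which of these changes matters. A plain phenyl group or a 4-aminophenyl group in the same place would help show whether the hydroxyl itself is needed for the lower number or whether any small group would serve as well.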